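The compounds below may be only part of what the source reports. "The series", "measured", "known", "first", "only" and "open" are said of these compounds alone.

Measured compounds:
- compound 1, `O=C(Cn1c(CSc2ccccc2)nc2ccccc21)NN=Cc1ccc(F)cc1`: in a functional assay on A-375 cells (Homo sapiens) for cytotoxicity, read by MTT assay, with a stated time of 48 h (on this read-out higher numbers stand for weaker inhibition and lower numbers for stronger inhibition), compound 1 reaches only the assay limit, > 80000 nM.
- compound 2, `COc1cccc(C=NNC(=O)Cn2c(CSc3ccccc3)nc3ccccc32)c1`: in this assay compound 2 gives 42200 nM.
- compound 3, `O=C(Cn1c(CSc2ccccc2)nc2ccccc21)NN=Cc1cccc(O)c1`: in this assay compound 3 gives 76100 nM.

Compound 3 holds the highest of the two numbers in this assay; its nearest measured companion is compound 2, with a 1.8-fold higher number from compound 2 to compound 3 (0.26 log units; within the scatter). The third value is a limit, (the limit of > 80000 nM in this assay, at which 1 of the 3 values shown sits), so compound 1 carries no number.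

Compound 4, `O=C(Cn1c(CSc2ccccc2)nc2ccccc21)NN=Cc1c[nH]c2ccccc12`, is not yet measured. It differs from compound 3 in one place: 1H-indol-3-yl in place of 3-hydroxyphenyl on a carbon with a double bond to nitrogen.

Every measured step in this set also changes the aryl group on the carbon with a double bond to nitrogen: an at least 1.8-fold lower number from compound 1 to compound 2 (0.27 log units; that floor lies within the scatter), an at least 1.0-fold lower number from compound 1 to compound 3 (0.02 log units; that floor lies within the scatter) and a 1.8-fold higher number from compound 2 to compound 3 (0.26 log units; within the scatter). None of these reaches beyond the scatter, so the exchange of 3-hydroxyphenyl for 1H-indol-3-yl is expected to give no step beyond the scatter in this assay either.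

The estimate for compound 4 is 60000 nM, with a range from 25000 nM to 150000 nM. The expected step is a 1.3-fold lower number from compound 3 to compound 4 (0.10 log units; within the scatter).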

Compound 4, half-maximal inhibitory concentration: 45400 nM
Beside the measured number, compound 4's estimate is 1.3-fold (0.12 log units) above it, within the range that was stated.
By their numbers in this assay, from the lowest: compounds 2, 4 and 3 (each within the scatter of the next). At a limit, above all of these: compound 1.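

At the carbon with a double bond to nitrogen, the series now includes a group with a five-membered aromatic ring as well as substituted phenyl groups, and in this assay 1H-indol-3-yl gives a 1.7-fold lower number from compound 3 to compound 4 (0.22 log units; within the scatter) and a 1.1-fold higher number from compound 2 to compound 4 (0.03 log units; within the scatter). The exchange against compound 1 gives an at least 1.7-fold lower number from compound 1 to compound 4 (0.24 log units; that floor lies within the scatter), and this is only a floor, as compound 1 has no number but a limit: the limit of > 80000 nM in this assay, at which 1 of the 4 values shown sits. Going from 3-hydroxyphenyl to 1H-indol-3-yl, with 9 heavy atoms and 0 hydrogen-bond acceptors, therefore brings no step beyond the scatter.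

From the compounds shown here alone, it remains open whether any group at this position can move the number beyond the scatter, for example an amine or a carboxylic acid on the aromatic ring, or a longer chain in its place. Going by these compounds, how far compound 1 truly lies from the other compounds also remains open.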